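From compound 2 to compound 3: adding a nitro group

A few compounds are considered here, and "the series" means these few. Any claim that something is new, unique, unknown or untested is made for them only; others in the source may bear on it.

Compound 1 `O=C(CCCCC1CCSS1)Nc1ccc([N+](=O)[O-])c(C(F)(F)F)c1`: "not active" (no number reported)
Compound 2 `O=C(CCCCC(S)CCS)Nc1cccc(C(F)(F)F)c1`: 8.86%

Going by the values given here, in a functional assay on HO8910 cells (Homo sapiens) for inhibition, read by MTT assay, with a stated time of 24 h, tested at 10 ug/mL (on this read-out lower numbers stand for less inhibition of growth and higher numbers for more inhibition of growth at the one concentration tested), compound 2 gives 8.86%, and this is the only number available so far. The other tested molecule, compound 1, gives "not active" (no number reported), with no number reported, so compound 2 cannot be ranked on a numerical scale.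

The next molecule, compound 3 `O=C(CCCCC(S)CCS)Nc1ccc([N+](=O)[O-])c(C(F)(F)F)c1`, differs from compound 2 in a single place: nitro in place of hydrogen on an aromatic carbon. This is nitro in place of hydrogen on an aromatic carbon, ortho to a trifluoromethyl group and para to a large group.

Among the compounds with values here, no two tested compounds differ in one place alone, so the data do not show directly what this change does. Any forecast is therefore rough. Compound 2 at 8.86% sits low on the scale, which leaves more room for a rise than for a fall. The step expected in this assay is a number 5.1 percentage points higher from compound 2 to compound 3 (within the scatter), a small rise that may well stay within the usual scatter. The estimated value for compound 3 is 14%, with an expected range from 0% to 35%.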

Compound 3, percent growth inhibition at one concentration: "not active" (no number reported)
The entry for compound 3 holds no number; no gap can be computed for the estimate.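

Going by these compounds alone, compound 3 gives "not active" (no number reported) in this assay and compound 2 gives 8.86% there, so no step from one to the other can be read. No measured property of these compounds bears on this result. Going by these compounds, whether adding the nitro group changes growth inhibition at all remains open.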